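A few compounds are considered here, and "the series" means these few. Any claim that something is new, unique, unknown or untested is made for them only; others in the source may bear on it.

In a functional assay on brain, read by spectrophotometry (on this read-out higher numbers stand for weaker inhibition and lower numbers for stronger inhibition), compound 1 (`Oc1ccccc1-c1nc(-c2ccccc2)c(-c2ccccc2)[nH]1`) gives 101000 nM and compound 2 (`Oc1cccc(-c2nc(-c3ccccc3)c(-c3ccccc3)[nH]2)c1`) gives 61800 nM, so the two numbers lie within the scatter of each other. Compound 3 (`Oc1ccc(-c2nc(-c3ccccc3)c(-c3ccccc3)[nH]2)cc1O`) differs from compound 2 in one place: hydroxy in place of hydrogen on an aromatic carbon. Among the compounds with values here, the only measured step that bears on this moves a hydroxy group rather than adding one, and it is a 1.6-fold lower number from compound 1 to compound 2 (0.21 log units; within the scatter). Within the data shown here, no measured step shows what a second hydroxy does, so no shift beyond the scatter is expected. The expected step is a 1.2-fold lower number from compound 2 to compound 3 (0.09 log units; within the scatter). Compound 3 is estimated at 50000 nM, with an expected range of 15000 nM to 150000 nM.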

Compound 3, half-maximal inhibitory concentration: 59400 nM
Compound 3: middle estimate off by 1.2-fold (0.07 log units), on the low side; the range from low to high includes it.
By their numbers in this assay, from the lowest: compounds 3, 2 and 1 (each within the scatter of the next).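

Adding a hydroxy ortho to the existing hydroxy group, which turns 3-hydroxyphenyl into 3,4-dihydroxyphenyl, keeps the number in this assay within the scatter (a 1.0-fold lower number from compound 2 to compound 3 (0.02 log units; within the scatter)). The earlier pair only moved a hydroxy, whereas this step shows that a second one brings no readable change here, and the comparison with the 2-hydroxyphenyl of compound 1 also stays within the scatter (a 1.7-fold lower number from compound 1 to compound 3 (0.23 log units; within the scatter)). No evidence is available that bears on this result. As far as these compounds go, whether a methoxy, an amine or a carboxylic acid at this position would shift the number beyond the scatter remains open.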